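This account rests on a few compounds, and the source may have more. Where it says the series, first, only, none or still open, it means among the compounds named here.

Series notes. Compound 1 `Cc1ccc(N(C)CC2CCC/C(=C\c3ccccc3)C2(O)c2ccccc2)cc1` carries a methyl(4-methylphenyl)amino group on the amine nitrogen; in a functional assay on the whole organism (Ear, strain Kunming) for inhibition, with Mus musculus as the target, with stated times of 1 h and 30 min, at a dose of 200 mg/kg by the oral route (on this read-out lower numbers stand for less inhibition and higher numbers for more inhibition at the one dose given (going by the name of the read-out)), compound 1 gives 66.7%. Compound 2 `Cc1cccc(N(C)CC2CCC/C(=C\c3ccccc3)C2(O)c2ccccc2)c1` differs from compound 1 by 3-methylphenyl in place of 4-methylphenyl on an amine nitrogen, and in this assay compound 2 gives 23.1%; this single change made a number 43.6 percentage points lower from compound 1 to compound 2 (beyond the scatter). Compound 3 `COc1ccc(C2(O)/C(=C/c3ccc(C)cc3)CCCC2CN(C)c2ccc(C)cc2)cc1` rests on a different core from compound 1; the difference between the two cores is not broken down here. In this assay compound 3 gives 29.9%, a number within the scatter of the value of compound 2 and well apart from that of compound 1. Compound 4 `COc1ccc(C2(O)/C(=C/c3ccc(C)cc3)CCCC2CN(C)c2cccc(C)c2)cc1`, not yet measured, differs from compound 3 by 3-methylphenyl in place of 4-methylphenyl on an amine nitrogen, the same change at the same place as that from compound 1 to compound 2. For compound 4 in this assay a downward step is expected, a number 17.9 percentage points lower from compound 3 to compound 4 (beyond the scatter), smaller than the earlier one because compound 3 starts from 29.9%, which leaves less room for the read-out to fall, even though the same change gave a number 43.6 percentage points lower from compound 1 to compound 2 (beyond the scatter). For the measured compounds named here, only one measured pair supports carrying this change onto the second core. Compound 4 is therefore estimated at 12%, between 0% and 30%.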

Compound 4, a percentage reported as inhibition, in the whole organism at one dose (the size of the read-out at that dose, not a potency): 24.5%
Compound 4: the middle estimate sits 12.5 percentage points below what was measured; the range from low to high includes it.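

In this assay, for the compounds shown here, 3-methylphenyl in place of 4-methylphenyl on the amine nitrogen gives a number 5.4 percentage points lower from compound 3 to compound 4 (within the scatter) on the second core, so there the change leaves no step that stands clear of the usual scatter. The size of the step therefore does not carry from one core to the other in this series, and the two pairs differ: the same change on two cores in this assay, a number 43.6 percentage points lower (beyond the scatter) from compound 1 to compound 2 and a number 5.4 percentage points lower (within the scatter) from compound 3 to compound 4, 38.2 percentage points apart, beyond the scatter of two such steps. This shows that the core matters for the outcome of this one change at this one dose, but it does not show which part of the core is responsible, why the steps differ, or how the change would behave on any further core.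

As far as these compounds go, it remains open which of the structural differences between the two cores goes with the smaller step. From the compounds shown here alone, it is also open whether an unsubstituted phenyl or a chlorophenyl on the amine nitrogen, or an ethyl in place of its methyl, would follow either pair.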